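The source may report more compounds than this note shows. Statements on the series, on what has been measured and on what is new or still open speak of the compounds shown alone.

Working notes on the series, read in an ADME assay on Akata cells (Homo sapiens) for cytotoxicity, with a stated time of 7 days; on this read-out higher numbers stand for lower toxicity in this test and lower numbers for higher toxicity in this test. The shared core carries isopropylamino in compound 1 `CC(C)Nc1nc(N)nc2c1ncn2/C=C1/CC1(CO)CO`, pyrrolidin-1-yl in compound 2 `Nc1nc(N2CCCC2)c2ncn(/C=C3/CC3(CO)CO)c2n1` and propoxy in compound 3 `CCCOc1nc(N)nc2c1ncn2/C=C1/CC1(CO)CO`. Compound 1 gives > 24000 nM, which is a limit. Compound 2 gives > 24000 nM, also a limit. Compound 3 gives > 20000 nM, again a limit, so compound 3 has no readable rank in the set. All readings so far stop there: the limit of > 20000 nM in this assay, at which 1 of the 3 values shown sits, and (the limit of > 24000 nM in this assay, at which 2 of the 3 values shown sit).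

Compound 4 `Nc1nc(SCc2ccccc2)c2ncn(/C=C3/CC3(CO)CO)c2n1` follows from compound 3 with benzylsulfanyl in place of propoxy on an aromatic carbon. The measured steps that bear on this change are those on the same carbon: a step that the two limits leave unreadable from compound 1 to compound 3 and a step that the two limits leave unreadable from compound 2 to compound 3. Going by the values given here, neither gives a size, and no measured compound carries benzylsulfanyl, so the expectation is weakly founded. The expected change is an at least 1.1-fold lower number from compound 3 to compound 4 (0.04 log units; that floor lies within the scatter), a small one towards lower numbers, and another limit is estimated to be more likely than a number. For compound 4 the estimate is 18000 nM, with an expected range of 6000 nM to 40000 nM.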

Compound 4, half-maximal cytotoxic concentration: > 20000 nM
Compound 4: no number, only a limit; the forecaster's own chance of this, stated with the estimate: 60%; middle value at least 1.1-fold (0.04 log units) from the limit.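

The steps to compound 4 from compound 1, compound 2 and compound 3 cannot be read in this assay. Compound 4 gives a limit and not a number: the limit of > 20000 nM in this assay, at which 2 of the 4 values shown sit.

The compounds shown leave open how far these four lie from one another, and whether any group on this aromatic carbon gives a readable number in this assay.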